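The compounds below may be only part of what the source reports. "The series", "measured", "known", "first", "only" and "open" are said of these compounds alone.

Compound 1, `COc1cc(NC(C)CCCNC(=O)Nc2ccc(Cl)c(C(F)(F)F)c2)c2ncccc2c1`, is a member of this series, but in an ADME assay on L6 cells (Rattus norvegicus) for cytotoxicity, read by resazurin assay, with a stated time of 70 h (on this read-out higher numbers stand for weaker inhibition and lower numbers for stronger inhibition), compound 1 gives "not determined" (no result reported). Going by the values given here, compound 2, `COc1cc(NC(C)CCCNC(=O)NNC(=O)/C=C/c2cccc(C(F)(F)F)c2)c2ncccc2c1`, is therefore the only one of the measured pair with a number: in this assay compound 2 gives 10600 nM, which places it as the single reference point that the series offers so far, with one further entry carrying no number at all.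

Compound 3, `COc1cc(NC(C)CCCNC(=O)NNC(=O)Nc2cccc(Cl)c2)c2ncccc2c1`, has not yet been measured. It differs from compound 2 in one place: (3-chlorophenyl)amino in place of 2-(3-(trifluoromethyl)phenyl)ethenyl on a carbonyl carbon. Among the compounds with values here, since no step between measured compounds is known, there is nothing to set a scale for the size of the change. With compound 2 at 10600 nM as the only anchor, the expectation is for a step from compound 2 to compound 3 of about a 1.4-fold higher number from compound 2 to compound 3 (0.15 log units; within the scatter), in the direction of weaker inhibition, which would still lie within the scatter of repeated measurements. On that basis compound 3 is expected to give about 15000 nM in this assay, with a plausible range from 5000 nM to 45000 nM.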

Compound 3, half-maximal inhibitory concentration: 58600 nM
The estimate for compound 3 lay 3.9-fold (0.59 log units) below the measured number; measured number above the stated range.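

this assay now has its first readable step: putting (3-chlorophenyl)amino in place of 2-(3-(trifluoromethyl)phenyl)ethenyl on the carbonyl carbon gives a 5.5-fold higher number from compound 2 to compound 3 (0.74 log units; beyond the scatter) and so moves the series toward weaker inhibition of the cells. This shows that what sits on this carbonyl carbon can shift the read-out beyond the usual scatter, but the change is a bundle rather than a single edit: the entering group has fewer heavy atoms, lacks the double bond outside the ring, adds one hydrogen-bond donor, and carries chlorine in place of fluorine. No measurement here ties the shift to any one of these differences.

The pair leaves open which part of the exchange matters, since the linking unit and the ring substituent change together. A phenylamino group or a 2-phenylethenyl group on the same carbonyl carbon, each with an unsubstituted ring, would help to separate the effect of the link from that of the chlorine or trifluoromethyl group.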